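A few compounds are considered here, and "the series" means these few. Any claim that something is new, unique, unknown or untested is made for them only; others in the source may bear on it.

Among the measured compounds shown here, compound 1 `Cc1nn(-c2ncnc3nc[nH]c23)c2c1C(OCc1ccccc1C#N)CC(=O)N2` gives 127 nM in a functional assay on HEK293 cells for agonist activity at G-protein coupled receptor 39 (Homo sapiens), read by scintillation proximity assay and inositol phosphate accumulation, with a stated time of 75 min (on this read-out lower numbers stand for an effect already at smaller amounts and higher numbers for an effect only at larger amounts of compound), the lowest of the three numbers measured so far. Compound 3 `Cc1nn(-c2ncnc3nc[nH]c23)c2c1C(NC(=O)c1ccccc1)CC(=O)N2` gives 158 nM and compound 2 `Cc1nn(-c2ncnc3nc[nH]c23)c2c1C(C(=O)NCc1ccccc1)CC(=O)N2` gives 2930 nM; the steps from the ether are a 1.2-fold higher number from compound 1 to compound 3 (0.09 log units; within the scatter) and a 23-fold higher number from compound 1 to compound 2 (1.36 log units; beyond the scatter), while a 19-fold lower number from compound 2 to compound 3 (1.27 log units; beyond the scatter) separates the two measured replacements of the ether. Compound 4 `Cc1nn(-c2ncnc3nc[nH]c23)c2c1C(OCc1cc(F)cc3c1OCOC3)CC(=O)N2` keeps the ether linkage of compound 1 and changes only the aryl part: a group of 11 heavy atoms (8 carbon, 2 oxygen, 1 fluorine; one six-membered non-aromatic ring with 2 hetero atoms, one six-membered aromatic ring of carbon only) in place of a group of 8 heavy atoms (7 carbon, 1 nitrogen; one six-membered aromatic ring of carbon only), on a saturated chain carbon bound to an oxygen on a saturated carbon. Every measured step alters the group on the saturated ring carbon itself, none the aryl part of the ether, so none bears directly on this change; the retained ether of compound 1 suggests the expected step of a 1.2-fold higher number from compound 1 to compound 4 (0.07 log units; within the scatter) is small, with its direction open. Compound 4 is estimated at 150 nM, range 45 nM to 500 nM.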

Compound 4, half-maximal effective concentration: 30 nM
Estimate against measurement, compound 4: 5.0-fold (0.70 log units) above; the whole stated range lies above it.
By their numbers in this assay, from the lowest: compound 4; then compounds 1 and 3 (each within the scatter of the next); then compound 2.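

With the ether linkage held, the aryl part alone moves the number in this assay and gives a 4.2-fold lower number from compound 1 to compound 4 (0.63 log units; beyond the scatter) as the measured step. This position therefore responds to the aryl group itself, not only to the linkage on the saturated ring carbon. The nitrile is also not required for a low number in this pair, as compound 4 carries none, but nothing measured accounts for the step.

The entering group changes the fluorine and the non-aromatic ring at once, so neither can be credited separately. From the compounds shown here alone, whether an unsubstituted phenyl, or a phenyl bearing an amine or a carboxylic acid, would hold the number stays open.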